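This account rests on a few compounds, and the source may have more. Where it says the series, first, only, none or still open, it means among the compounds named here.

Measured so far in a functional assay on HCT-116 cells (Homo sapiens) for cytotoxicity, read by scintillation counting and thymidine incorporation, with a stated time of 72 h; a higher number here means a weaker inhibitor, a lower number a stronger inhibitor:
Compound 1 `COc1cc(OC)cc(C(=CCCN(C)C)c2ccc(OC)c(OC)c2)c1` gives > 10000 nM, a limit of the assay rather than a number.
Compound 2 `COc1ccc(C(=CC#N)c2cc(OC)cc(OC)c2)cc1` gives 1.2 nM.
Compound 3 `CCOc1cc(C(=C(F)F)c2ccc(OC)c(O)c2)ccc1OC` gives 74 nM.

Compound 1 stands at the limit (the limit of > 10000 nM in this assay, at which 1 of the 3 values shown sits), so only a ceiling is known for it. Compound 2 and compound 3, which carry other groups on the chain carbon, both give numbers well inside the measurable range.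

Compound 4 `COC(=O)C=C(c1cc(OC)cc(OC)c1)c1ccc(OC)c(OC)c1` differs from compound 1 by methoxycarbonyl in place of 2-(dimethylamino)ethyl on a double-bonded chain carbon bound to a double-bonded chain carbon. Among the compounds with values here, no measured step of this kind is available, so the size is uncertain. Given compound 2 at 1.2 nM and compound 3 at 74 nM, a large step toward stronger inhibition is expected, an at least 200-fold lower number from compound 1 to compound 4 (2.30 log units; beyond the scatter). Compound 4 is estimated at 50 nM, in the range 5 nM to 500 nM.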

Compound 4, half-maximal inhibitory concentration: > 10000 nM
Compound 4: a limit, no number; the forecaster's own chance of this, stated with the estimate: 10%; middle value at least 200-fold (2.30 log units) away from the limit.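

Within the data shown here, compound 1 and compound 4 both give limits rather than numbers, so no step between them can be read: the limit of > 10000 nM in this assay, at which 2 of the 4 values shown sit. The compounds shown leave open how methoxycarbonyl and 2-(dimethylamino)ethyl compare at this place on the shared core.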